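A few compounds are considered here, and "the series" means these few. Any claim that something is new, unique, unknown or untested is made for them only; others in the source may bear on it.

Measured so far in an ADME assay (liver) for metabolic stability, with Liver microsome (Homo sapiens) as the target, read by LC-MS, using microsomes, with a stated time of 1 h, tested at 5 uM; on this read-out lower numbers stand for a less stable compound and higher numbers for a more stable compound:

- compound 1 `Cc1ccc(C)c(N2CCN(C(=O)c3oc(C)nc3-c3ccccc3)CC2)c1` gives 33.8%
- compound 2 `Cc1nc(-c2ccc(F)cc2)c(C(=O)N2CCN(c3cc(Cl)cc(Cl)c3)CC2)o1` gives 71.8%
- compound 3 `CCC[C@H](Nc1nc(-c2ccc(NC(=O)NCC)c(OC)c2)ncc1C)c1cccnc1` gives 54.6%

Compound 1 stands lowest of the three at 33.8%, and both compound 3 and compound 2 lie above it by more than the scatter. The next compound to be read is compound 4 `COc1cc(OC)cc(N2CCN(C(=O)c3oc(C)nc3-c3ccccc3)CC2)c1`, which carries 3,5-dimethoxyphenyl in place of 2,5-dimethylphenyl on an amine nitrogen in a ring, with the rest of compound 1 unchanged.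

Within the data shown here, no two measured compounds differ in one place only, so the series offers no direct guide to this replacement. The expectation therefore stays close to compound 1 at 33.8% in this assay, with no step beyond the scatter foreseen in either direction. The estimated step is a number 2.8 percentage points lower from compound 1 to compound 4 (within the scatter), and its uncertainty is wide. For compound 4 the estimate is 31%, with an expected range from 14% to 50%.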

Compound 4, percent of the compound remaining: 15.8%
For compound 4 the middle estimate is 15.2 percentage points above the measured one, and the stated range covers the measured number.
By their numbers in this assay, from the lowest: compound 4; then compound 1; then compound 3; then compound 2.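

In this assay the group on an amine nitrogen in a ring is shown to matter with the rest of compound 1 unchanged: 3,5-dimethoxyphenyl in place of 2,5-dimethylphenyl gives a number 18 percentage points lower from compound 1 to compound 4 (beyond the scatter) as the first one-place step in the series. The exchange swaps both the substituent and its placement on the six-membered aromatic ring, so this single step cannot assign the loss to either one. Nothing at hand bears on why the number falls, and the reason stays unknown.

A 3,5-dimethylphenyl or a 2,5-dimethoxyphenyl group on the same nitrogen would separate the methoxy groups from their placement. Going by these compounds, whether an unsubstituted phenyl at this position reads closer to compound 1 or to compound 4 also remains open.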